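Trifluoromethyl in place of nitro on compound 3

The compounds below may be only part of what the source reports. "The series", "measured", "known", "first", "only" and "open" are said of these compounds alone.

In a functional assay on MCF7 cells (Homo sapiens) for antiproliferative activity, read by MTT assay, with a stated time of 72 h (on this read-out lower numbers stand for stronger inhibition and higher numbers for weaker inhibition), compound 3 (`Nc1nc(N)c2cc(CSC(=S)N3CCN(c4ccc([N+](=O)[O-])cc4)CC3)ccc2n1`) gives 1470 nM as the lowest of three numbers, against compound 2 (`Nc1nc(N)c2cc(CSC(=S)N3CCN(c4ccccc4Cl)CC3)ccc2n1`) at 3190 nM and compound 1 (`Cc1ccccc1N1CCN(C(=S)SCc2ccc3nc(N)nc(N)c3c2)CC1`) at 4230 nM on the same read-out. Compound 4 (`Nc1nc(N)c2cc(CSC(=S)N3CCN(c4ccc(C(F)(F)F)cc4)CC3)ccc2n1`) comes next: trifluoromethyl in place of nitro on an aromatic carbon that is, trifluoromethyl in place of nitro on an aromatic carbon. Among the compounds with values here, no measured step isolates the nitro group. The nearest evidence is modest: a 2.2-fold lower number from compound 2 to compound 3 (0.34 log units; beyond the scatter) and a 2.9-fold lower number from compound 1 to compound 3 (0.46 log units; beyond the scatter) while a 1.3-fold lower number from compound 1 to compound 2 (0.12 log units; within the scatter) stays within the scatter. From these steps only a small shift is expected in this assay and a slightly higher number is more likely than a lower one. The expected step is a 1.3-fold higher number from compound 3 to compound 4 (0.11 log units; within the scatter) and no more. For compound 4 the estimate is 1900 nM with an expected range from 850 nM to 4200 nM in this assay.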

Compound 4, half-maximal inhibitory concentration: 7400 nM
Beside the measured number, compound 4's estimate is 3.9-fold (0.59 log units) below it; the whole stated range lies below it.
By their numbers in this assay, from the lowest: compound 3; then compounds 2, 1 and 4 (each within the scatter of the next, the first and the last beyond it).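

Within the data shown here, the largest step so far in this assay sits at this aromatic carbon, with a 5.0-fold higher number from compound 3 to compound 4 (0.70 log units; beyond the scatter) on leaving nitro for trifluoromethyl, so the low number of compound 3 belongs to the 4-nitrophenyl group and not to just any substituent here. Set against the other aryl groups, 4-(trifluoromethyl)phenyl gives a 2.3-fold higher number from compound 2 to compound 4 (0.37 log units; beyond the scatter) and a 1.7-fold higher number from compound 1 to compound 4 (0.24 log units; within the scatter) with no gain over either. Nothing available explains the difference between nitro and trifluoromethyl at this place.

On these data alone, whether a nitrile, an amine or a carboxylic acid at this aromatic carbon would stay close to compound 3 remains open. Also open, as far as these compounds go, is whether nitro keeps its standing elsewhere on the ring.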